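Methyl for Cyano on the Triazole Ring

This account rests on a few compounds, and the source may have more. Where it says the series, first, only, none or still open, it means among the compounds named here.

The two measured compounds share one core, shown for compound 1 as `CNc1nc(NC2(C#N)CCCCC2)nc(N(C)C)n1` and for compound 2 as `CNc1nc(NC2(C#N)CCCCC2)nc(-n2cnc(C#N)n2)n1`. In an in vitro assay on Sf21 cells for inhibition of high affinity 3',5'-cyclic-AMP phosphodiesterase 7A (Homo sapiens) (a lower number here means a stronger inhibitor, a higher number a weaker inhibitor), compound 1 gives only a limit of the assay, > 5000 nM. In this assay compound 2 likewise gives only a limit of the assay, > 5000 nM. Among the measured compounds shown here, the one measured step, a step that the two limits leave unreadable from compound 1 to compound 2, cannot be read in size or direction since both of its ends sit at the limit of > 5000 nM in this assay, at which 2 of the 2 values shown sit.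

Compound 3, `CNc1nc(NC2(C#N)CCCCC2)nc(-n2cnc(C)n2)n1`, differs from compound 2 by methyl in place of cyano on an aromatic carbon. No measured step bears on this change: the only step shown is unreadable, and both values shown rest at the limit of > 5000 nM in this assay, at which 2 of the 2 values shown sit. Whether the change from cyano to methyl moves the inhibitory concentration beyond the scatter is therefore open. The most likely outcome for compound 3 is that it again reports only a limit, so the step expected from it, a step that the limit leaves unreadable from compound 2 to compound 3, is no more than a guess. Compound 3 is estimated at 10000 nM, within a range of 3000 nM to 50000 nM.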

Compound 3, half-maximal inhibitory concentration: > 5000 nM
Compound 3 ended at the assay's limit; the forecaster's own chance of this, stated with the estimate: 75%; the middle value lies beyond the limit too.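

Compound 3, like compound 1 and compound 2, gives only a limit of the assay in this assay, so none of the steps among these three compounds can be read in size or direction: the limit of > 5000 nM in this assay, at which 3 of the 3 values shown sit.

The compounds shown leave open how strongly any of the three inhibits and whether dimethylamino, 3-cyano-1H-1,2,4-triazol-1-yl or 3-methyl-1H-1,2,4-triazol-1-yl on the shared core makes any difference in this assay.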